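This account rests on a few compounds, and the source may have more. Where it says the series, first, only, none or still open, it means among the compounds named here.

Measured compounds:
Compound 1, `CC(=O)N(C)c1ccc2[nH]c(-c3n[nH]c4ccccc34)cc2n1`: in a functional assay on A549 cells (Homo sapiens) for antiproliferative activity, read by MTT assay, with a stated time of 72 h (a higher number here means a weaker inhibitor, a lower number a stronger inhibitor), compound 1 gives > 50000 nM, a limit of the assay.
Compound 2, `CN(C(=O)c1ccc(Br)cc1)c1ccc2[nH]c(-c3n[nH]c4ccccc34)cc2n1`: in this assay compound 2 gives 4250 nM.

Compound 2 holds the only number shown. The value of compound 1 is a limit (the limit of > 50000 nM in this assay, at which 1 of the 2 values shown sits), so compound 2 cannot be ranked against another number. Going by the values given here, the single measured step, an at least 11-fold lower number from compound 1 to compound 2 (1.07 log units; beyond the scatter), is large. Compound 3, `COc1ccc(C(=O)N(C)c2ccc3[nH]c(-c4n[nH]c5ccccc45)cc3n2)cc1`, differs from compound 2 by methoxy in place of bromo on an aromatic carbon. The measured step concerns the whole 4-bromophenyl group entering on the carbonyl carbon, whereas the step to compound 3 only exchanges a substituent on that ring; it shows that the aryl group matters, but gives no guide to what its substituent does. Compound 3 is therefore expected to stay close to compound 2, with the estimated step of a 1.4-fold higher number from compound 2 to compound 3 (0.15 log units; within the scatter) near the scatter. In this assay compound 3 is estimated at 6000 nM, between 2000 nM and 18000 nM.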

Compound 3, half-maximal inhibitory concentration: 14600 nM
The estimate for compound 3 lay 2.4-fold (0.39 log units) below the measured number; the range from low to high includes it.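

In this assay, the substituent on this ring is not a matter of indifference: exchanging bromo for methoxy on the aromatic carbon para to a large group gives a 3.4-fold higher number from compound 2 to compound 3 (0.54 log units; beyond the scatter). Going by these compounds alone, the earlier pair showed only that the whole aryl group counts, whereas this step shows that the outcome also depends on what that carbon carries, and the 4-methoxyphenyl group still gives an at least 3.4-fold lower number from compound 1 to compound 3 (0.53 log units; beyond the scatter). That second step rests on a limit of the assay for compound 1, not on a number: the limit of > 50000 nM in this assay, at which 1 of the 3 values shown sits.

From the compounds shown here alone, with only bromo and methoxy to compare, what sets the difference between them remains open. Going by these compounds, it is also open what an amine or a carboxylic acid on that same aromatic carbon would do, and whether a chlorine at that carbon would track with bromo.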